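The source may hold more compounds than are shown below. What is called first, only, known or untested is meant among the compounds shown, and "the series" means these compounds.

Of the compounds shown here, two that share one core have been tested in a functional assay on cells (T-cell, Homo sapiens) for inhibition; on this read-out higher numbers stand for weaker inhibition and lower numbers for stronger inhibition. Compound 1 has the structure `CCOc1nc(N)nc2ncc(-c3ccc(Cl)c(Cl)c3)nc12` and in this assay compound 1 gives > 10000 nM — a limit of the assay rather than a number, namely (the limit of > 10000 nM in this assay, at which 1 of the 2 values shown sits). For the measured compounds named here, compound 2 has the structure `COc1ccc(-c2cnc3nc(N)nc(N4CCN(C(=O)c5ccccc5)CC4)c3n2)cc1OC` and is the one compound with an actual number: in this assay compound 2 gives 400 nM. That number stands alone, with nothing measured beside it to rank it against, since the other value shown is a limit rather than a number.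

Compound 3 has the structure `COc1ccc(-c2cnc3nc(N)nc(N4CCN(C(=O)Nc5ccccc5)CC4)c3n2)cc1OC` and has not yet been measured. It differs from compound 2 in one place: anilino in place of phenyl on a carbonyl carbon. Cut one bond further out, the same change reads benzoyl to phenylcarbamoyl. Going by the values given here, no step between measured compounds is available to show what such a swap does, so any expectation rests on the change itself and on the number for compound 2 alone. The expected step from compound 2 to compound 3 in this assay is no change at the digits printed from compound 2 to compound 3 (within the scatter), which means no movement beyond the usual scatter in either direction. Compound 3 is therefore estimated at 400 nM, within a range from 130 nM to 1500 nM.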

Compound 3, half-maximal inhibitory concentration: 3.4 nM
Estimate against measurement, compound 3: 120-fold (2.07 log units) above; measured number outside the range, below it.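

In this assay, anilino in place of phenyl on a carbonyl carbon gives a 120-fold lower number from compound 2 to compound 3 (2.07 log units; beyond the scatter) and lies well beyond the scatter, so the group at this position, on a carbonyl carbon whose other neighbour is an amide-type nitrogen in a ring, has a strong hold on the read-out. For the compounds shown here, the change looks small on paper: benzoyl becomes phenylcarbamoyl, the six-membered aromatic ring of carbon stays, and what enters is one nitrogen bearing one hydrogen-bond donor, yet the earlier compounds offered no step that could reveal such sensitivity at this place. The measurements shown give no reason for the size of this step.

As far as these compounds go, whether the amide hydrogen matters, or only the added atom, remains open, and a phenoxy group with oxygen in that spot or a benzyl group with carbon there would help to separate the two. Also open, from the compounds shown here alone, is whether the aromatic ring itself is needed, which a cyclohexylamino group could test, and whether a methyl or chlorine on the ring of the anilino group would keep the gain.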